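The compounds below may be only part of what the source reports. "The series", "measured", "known", "first", "only" and "open" are said of these compounds alone.

In a functional assay on NCI-H460 cells (Homo sapiens) for cytotoxicity, read by MTT assay (on this read-out higher numbers stand for weaker inhibition and lower numbers for stronger inhibition), the measured compounds stand as follows:
Compound 1 `Cc1cc(S(=O)(=O)N2C(=O)N[C@@H](c3ccccc3)C2C)ccc1NC(=O)c1ccc(N)cc1` gives > 10000 nM, a limit of the assay.
Compound 2 `CCOC(=O)Nc1ccc(S(=O)(=O)N2C(=O)N[C@@H](c3ccccc3)C2C)cc1Cl` gives 6000 nM.
Compound 3 `CC1[C@H](c2ccccc2)NC(=O)N1S(=O)(=O)c1ccc(NC(=O)c2ccc(N)cc2)c(Cl)c1` gives > 10000 nM, a limit of the assay.

Compound 2 is the only one of the three with a number; the other two sit at the limit of > 10000 nM in this assay, at which 2 of the 3 values shown sit. Compound 2 and compound 3 share the same core and differ in ethoxy in place of 4-aminophenyl on a carbonyl carbon, and this shows as an at least 1.6-fold higher number from compound 2 to compound 3 (0.22 log units; that floor lies within the scatter). Compound 3 and compound 1 differ in methyl in place of chloro on an aromatic carbon, and the step between them is a step that the two limits leave unreadable from compound 3 to compound 1, unreadable because both sit at the limit of > 10000 nM in this assay, at which 2 of the 3 values shown sit.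

Compound 4 `CCOC(=O)Nc1ccc(S(=O)(=O)N2C(=O)N[C@@H](c3ccccc3)C2C)cc1C` has not been measured in this assay. It differs from compound 2 in methyl in place of chloro on an aromatic carbon. Among the measured compounds shown here, this is the same kind of change as the one from compound 3 to compound 1, but the place around it differs: in compound 3 the carbon that changes is ortho to a ((4-aminophenyl)carbonyl)amino group, whereas in compound 2 it is ortho to a (ethoxycarbonyl)amino group. For the measured compounds named here, the one precedent for this kind of change gives no size, so the expectation for compound 4 rests on the value of compound 2 in this assay, 6000 nM, with wide room on either side. Compound 4 is expected to show a step of a 1.2-fold higher number from compound 2 to compound 4 (0.07 log units; within the scatter). Compound 4 is therefore estimated at 7000 nM in this assay, expected to fall between 2500 nM and 20000 nM.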

Compound 4, half-maximal inhibitory concentration: 5000 nM
Compound 4: the middle estimate sits 1.4-fold (0.15 log units) above what was measured; the range from low to high includes it.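

In this assay, among the compounds shown here, methyl in place of chloro on the aromatic carbon gives a 1.2-fold lower number from compound 2 to compound 4 (0.08 log units; within the scatter), while the same change from compound 3 to compound 1 cannot be read, since both of those values are limits of the assay: the limit of > 10000 nM in this assay, at which 2 of the 4 values shown sit. Ethoxy in place of 4-aminophenyl on the carbonyl carbon gives an at least 2.0-fold lower number from compound 1 to compound 4 (0.30 log units; that floor lies within the scatter), and this can be set beside the reverse change on the other core: the same change on two cores in this assay, an at least 1.6-fold higher number (0.22 log units; that floor lies within the scatter) from compound 2 to compound 3 and an at least 2.0-fold higher number (0.30 log units; that floor lies within the scatter) from compound 4 to compound 1; the limit leaves it open whether they differ The two cores therefore show no disagreement over the carbonyl change, but they do not show that it carries across with the same size, or that it exceeds the usual scatter on either core, and the chloro-to-methyl change has a readable size on only one core.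

On these data alone, it remains open what other groups on the carbonyl carbon would give, such as methoxy, a longer chain or an aminophenyl carrying a further substituent, and how far the compounds with 4-aminophenyl lie beyond the limit. As far as these compounds go, it also remains open whether a hydrogen, fluoro or bromo on the aromatic carbon would give a value distinct from those of compound 2 and compound 4.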